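This account rests on a few compounds, and the source may have more. Where it says the series, first, only, none or still open, it means among the compounds named here.

Of the compounds shown here, two built on a shared core have been measured in a functional assay on HEp-2 cells (Homo sapiens) for antiproliferative activity, read by MTT assay, with a stated time of 72 h; a higher number here means a weaker inhibitor, a lower number a stronger inhibitor. Compound 1 `O=c1c(SC(=S)N2CCCC2)coc2ccc(Cl)cc12` gives 26000 nM in this assay, while compound 2 `O=c1c(SC(=S)N2CCCCC2)coc2ccccc12` gives 5800 nM. Compound 2 therefore holds the lowest of the two numbers, and its nearest neighbour, compound 1, sits at a higher number by a gap beyond the usual scatter. Because these two structures differ in more than one place, that gap cannot be assigned to any single change.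

Compound 3 `O=c1c(SC(=S)N2CCCCC2)coc2ccc(Cl)cc12` has not yet been measured; it differs from compound 2 by chloro in place of hydrogen on an aromatic carbon. Going by the values given here, no single-change step between measured compounds is available to guide this. Compound 1, which also carries the chloro, shows the higher number, but it differs from compound 2 elsewhere as well, so only a modest weakening is expected, and the expected step is a 1.6-fold higher number from compound 2 to compound 3 (0.19 log units; within the scatter). Compound 3 is accordingly estimated at 9000 nM, with a range of 3000 nM to 27000 nM.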

Compound 3, half-maximal inhibitory concentration: 12200 nM
Beside the measured number, compound 3's estimate is 1.4-fold (0.13 log units) below it, and the stated range covers the measured number.
By their numbers in this assay, from the lowest: compound 2; then compound 3; then compound 1.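

In this assay, going by these compounds alone, chloro in place of hydrogen on an aromatic carbon, meta to a fused ring and para to a fused ring, gives a 2.1-fold higher number from compound 2 to compound 3 (0.32 log units; beyond the scatter), the first reading of this position through a single change, and a modest weakening. With the chloro held in place, piperidin-1-yl in place of pyrrolidin-1-yl on a thiocarbonyl carbon gives a 2.1-fold lower number from compound 1 to compound 3 (0.33 log units; beyond the scatter), so the gap between compound 1 and compound 2 now resolves into two modest single changes, both favouring the group compound 2 carries. Nothing available explains either step.

As far as these compounds go, whether the chloro step keeps its size with pyrrolidin-1-yl on the thiocarbonyl carbon remains open. So does how a fluoro or methoxy group at this position, or a morpholin-4-yl group on the thiocarbonyl carbon, would compare.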